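Hydroxy to methoxy on compound 2

The source may report more compounds than this note shows. Statements on the series, on what has been measured and on what is new or still open speak of the compounds shown alone.

Measured so far in an ADME assay on microsomes from liver (Rattus norvegicus) for metabolic stability, read by LC-MS, with a stated time of 1 h, at 37 degrees C, tested at 4 uM (on this read-out higher numbers stand for a more stable compound and lower numbers for a less stable compound), for three compounds:
compound 1 `CN(C)C(=O)c1cc(-c2cccc(COc3ccc4c(=O)n(C5CCCC5)sc4c3)c2)ccc1Cl` gives 92%
compound 2 `O=C(O)c1cc(-c2cccc(COc3ccc4c(c3)CN(C3CCCC3)C4=O)c2)ccc1O` gives 9%
compound 3 `O=C(O)c1cc(-c2cccc(COc3ccc4c(=O)n(C5CCC5)sc4c3)c2)ccc1Cl` gives 67%

Compound 2 at 9% is the lowest of the three. Compound 3 stands at 67% and compound 1 at 92%. In this small set the gaps from compound 2 to these two compounds both lie beyond the scatter, and the gap to compound 1 is the larger. Compound 4 `COc1ccc(-c2cccc(COc3ccc4c(c3)CN(C3CCCC3)C4=O)c2)cc1C(=O)O` differs from compound 2 by methyl in place of hydrogen on an oxygen on an aromatic ring in one place, with methyl in place of hydrogen on an oxygen on an aromatic ring, hydroxy to methoxy. Among the measured compounds shown here, no measured pair shows this change. In this assay the estimated step of a number 7 percentage points higher from compound 2 to compound 4 (within the scatter) is upward and is not expected to pass the scatter. Compound 4 is estimated at 16% with an expected range of 4% to 42% in this read-out.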

Compound 4, percent of the compound remaining: 84%
The estimate for compound 4 lay 68 percentage points below the measured number, outside the stated range (above it).
By their numbers in this assay, from the lowest: compound 2; then compound 3; then compounds 4 and 1 (each within the scatter of the next).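

In this assay, hydroxy to methoxy gives a number 75 percentage points higher from compound 2 to compound 4 (beyond the scatter). The earlier compounds shown here differed from compound 2 in several places, so none could tie its low number to one place; this step ties it to the hydrogen on an oxygen on an aromatic ring. Among the compounds shown here, nothing available explains why replacing that hydrogen with methyl moves the number so far.

On these data alone, whether a longer chain such as ethoxy, or an amine, in this place would give a similar number stays open. So does whether the same change would have a similar effect on the core of compound 3.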